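Swapping the aryl group on a saturated ring carbon

The compounds below may be only part of what the source reports. "The series", "measured", "known", "first", "only" and "open" are said of these compounds alone.

Compound 1 `N#CC1=C(N)N(c2ccc(S(N)(=O)=O)cc2)C2=C(CCCC2)C1c1ccc(O)cc1` gives 100% in a functional assay on Ehrlich cells (Mus musculus) for cytotoxicity, read by trypan blue exclusion, with a stated time of 2 h, tested at 100 ug/mL; a lower number here means a weaker effect, a higher number a stronger effect of the compound at the concentration tested.
Compound 2 `N#CC1=C(N)N(c2ccc(S(N)(=O)=O)cc2)C2=C(CCCC2)C1c1ccc(Cl)cc1Cl` gives 70% in this assay.

Of these two numbers, compound 2 stands lowest. Among the compounds with values here, the single measured step, a number 30 percentage points lower from compound 1 to compound 2 (beyond the scatter), is modest and lies beyond the scatter, so the aryl group on the saturated ring carbon does shift the read-out.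

Compound 3 `N#CC1=C(N)N(c2ccc(S(N)(=O)=O)cc2)C2=C(CCCC2)C1c1c(O)ccc2ccccc12` differs from compound 2 in one place: 2-hydroxynaphthalen-1-yl in place of 2,4-dichlorophenyl on a saturated ring carbon. Within the data shown here, the step from compound 1 to compound 2 is the only guide, and it points the other way: the entering group again carries a hydroxyl, which compound 1 also bears. From the compounds shown here alone, a rise is therefore expected, because compound 1 gave 100%, though the added second aromatic ring is untested here. The expected step is a number 15 percentage points higher from compound 2 to compound 3 (beyond the scatter). Compound 3 is estimated at 85%, within a range from 55% to 100%.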

Compound 3, a percentage reported as activity, at one concentration (the size of the read-out at that concentration, not a potency): 50%
The estimate for compound 3 lay 35 percentage points above the measured number; the whole stated range lies above it.
By their numbers in this assay, from the lowest: compound 3; then compound 2; then compound 1.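

Placing 2-hydroxynaphthalen-1-yl on the saturated ring carbon instead of 4-hydroxyphenyl gives a clear fall in this assay (a number 50 percentage points lower from compound 1 to compound 3 (beyond the scatter)), so a hydroxyl on the aryl group does not by itself keep the reading high. Placing the same group there instead of 2,4-dichlorophenyl also lowers the reading (a number 20 percentage points lower from compound 2 to compound 3 (beyond the scatter)), so compound 2, whose aryl group has no hydroxyl, reads above compound 3, and hydroxyl-bearing aryl groups stand at both ends of the order. Nothing measured here explains why this position responds in this way.

Still open, from the compounds shown here alone, is how much of the fall belongs to the hydroxyl and how much to the second aromatic ring, a question that plain naphthalen-1-yl could help to separate. Also open, going by these compounds, is how the reading would change with an amine or a methoxy group in place of the hydroxyl.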